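The source may hold more compounds than are shown below. What is called first, only, known or untested is meant among the compounds shown, and "the series" means these compounds.

In a functional assay on HEK293 cells (Homo sapiens) for cytotoxicity (on this read-out higher numbers stand for lower toxicity in this test and lower numbers for higher toxicity in this test), compound 2 `COc1ccc([C@H]2CC(=O)N(c3cccc(NS(=O)(=O)c4cc(C)ccc4OC)c3)C2)cc1OC1CCCC1` gives > 10000 nM, which is a limit of the assay rather than a measured number. Compound 1 `COc1ccc([C@H]2CC(=O)N(c3cccc(N(C)C)c3)C2)cc1OC1CCCC1` shares the same core and in this assay gives > 10000 nM, also a limit. Both measured compounds therefore stand together at the edge of what this assay reports, (the limit of > 10000 nM in this assay, at which 2 of the 2 values shown sit), and nothing yet shows a difference between them.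

Compound 3 `COc1ccc([C@H]2CC(=O)N(c3cccc(NS(=O)(=O)c4c(Br)nn(C)c4Cl)c3)C2)cc1OC1CCCC1` is the next compound, differing from compound 2 by 3-bromo-5-chloro-1-methyl-1H-pyrazol-4-yl in place of 2-methoxy-5-methylphenyl on a sulfonyl sulfur. Among the measured compounds shown here, no measured step between any two compounds is available, so the size of the step from compound 2 to compound 3 can only be expected, not read off. Because both known values sit at the limit (the limit of > 10000 nM in this assay, at which 2 of the 2 values shown sit), compound 3 is expected to stay near that limit as well, with no step beyond the scatter in either direction. Compound 3 is expected to give about 12000 nM, between 4000 nM and 40000 nM. The step that the limit leaves unreadable from compound 2 to compound 3 is expected to be small.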

Compound 3, half-maximal cytotoxic concentration: > 10000 nM
Compound 3 was reported as a limit (the forecaster's own chance of this, stated with the estimate: 70%); the middle value lies beyond the limit too.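

No step can be read between compound 1, compound 2 and compound 3, since all three stop at the same limit in this assay: the limit of > 10000 nM in this assay, at which 3 of the 3 values shown sit. As far as these compounds go, whether the three compounds differ at all on this read-out, and which of them would prove more toxic, remains open.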